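Swapping an Ester for a Dichlorophenyl Group on the Shared Core

This account rests on a few compounds, and the source may have more. Where it says the series, first, only, none or still open, it means among the compounds named here.

Compound 1, `O=C(CCCCC1CCSS1)NCc1cn(CCCOc2ccc3ccc(=O)oc3c2)nn1`: in a functional assay on PC-12 cells (Rattus norvegicus) for cytotoxicity, read by MTT assay, with stated times of 3 h and 2 h, tested at 1 uM (on this read-out higher numbers stand for a stronger effect at the one concentration tested and lower numbers for a weaker effect), compound 1 gives 37.2%.
Compound 2, `CCOC(=O)c1cc2ccc(OCCCCCn3cc(CNC(=O)CCCCC4CCSS4)nn3)cc2oc1=O`: in this assay compound 2 gives 35.1%.

Compound 2 stands lowest of the two numbers, with compound 1 the nearest, a little higher, but that gap lies within the scatter, so the two values show no difference that can be read as an order. Compound 3, `O=C(CCCCC1CCSS1)NCc1cn(CCCCCOc2ccc3cc(-c4ccc(Cl)c(Cl)c4)c(=O)oc3c2)nn1`, has not yet been measured in this assay. It differs from compound 2 in one place: 3,4-dichlorophenyl in place of ethoxycarbonyl on an aromatic carbon. Going by the values given here, no pair of measured compounds isolates this exchange, and the two measured values sit close together despite their own structural differences. The expectation therefore rests on compound 2 alone, and the expected step of a number 0.9 percentage points higher from compound 2 to compound 3 (within the scatter) is none beyond the scatter, in no particular direction. Compound 3 is estimated to give 36% in this assay, with a range from 20% to 55%.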

Compound 3, a percentage reported as activity, at one concentration (the size of the read-out at that concentration, not a potency): 50.6%
Estimate against measurement, compound 3: 14.6 percentage points below; the measured number falls inside the stated range.
By their numbers in this assay, from the lowest: compounds 2 and 1 (each within the scatter of the next); then compound 3.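

In this assay, 3,4-dichlorophenyl in place of ethoxycarbonyl on this aromatic carbon, two atoms from the ring oxygen, gives a number 15.5 percentage points higher from compound 2 to compound 3 (beyond the scatter). Going by these compounds alone, this is the first sign that the read-out responds to what sits at this position, since compound 1 and compound 2 differ in more than one place and offer no exchange here that can be read on its own. Nothing measured here accounts for the step.

The compounds shown leave open whether the aromatic ring or its two chlorines carry the step, which an unsubstituted phenyl or a monochlorophenyl at this carbon would begin to separate. They also do not show how a carboxylic acid or an amine would read at the same position, or whether the step holds on a shorter chain.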